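A Cyclohexyl Swap Under a Half-Life Limit

The compounds below may be only part of what the source reports. "The series", "measured", "known", "first", "only" and "open" are said of these compounds alone.

Compound 1 `CS(=O)(=O)Nc1ccc2c(c1)S(=O)(=O)N=C(C1=C(O)[C@@H]3[C@@H]4CC[C@@H](C4)[C@@H]3N(Cc3ccccc3F)C1=O)N2`, compound 2 `CS(=O)(=O)Nc1ccc2c(c1)S(=O)(=O)N=C(C1=C(O)[C@@H]3[C@@H]4CC[C@@H](C4)[C@@H]3N(Cc3ccc(F)c(Cl)c3)C1=O)N2` and compound 3 `CS(=O)(=O)Nc1ccc2c(c1)S(=O)(=O)N=C(C1=C(O)[C@@H]3[C@@H]4CC[C@@H](C4)[C@@H]3N(Cc3ccc(F)c(F)c3F)C1=O)N2` share one core and differ only in the aromatic ring on a saturated chain carbon bound to an amide-type nitrogen in a ring. In an in vitro ADME assay on microsomes from liver (Homo sapiens) for metabolic stability, tested at 1 uM (on this read-out higher numbers stand for a longer-lived compound and lower numbers for a shorter-lived compound), compound 1 gives > 1 h, which is a limit and not a number. Compound 2 gives > 1 h, again a limit. Compound 3 gives > 1 h, also a limit. The picture so far is thus (the limit of > 1 h in this assay, at which 3 of the 3 values shown sit).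

Compound 4 `CS(=O)(=O)Nc1ccc2c(c1)S(=O)(=O)N=C(C1=C(O)[C@@H]3[C@@H]4CC[C@@H](C4)[C@@H]3N(CC3CCCCC3)C1=O)N2` brings a new kind of change: cyclohexyl in place of 2,3,4-trifluorophenyl on a saturated chain carbon bound to an amide-type nitrogen in a ring. The nearest measured comparisons are a step that the two limits leave unreadable from compound 1 to compound 3 and a step that the two limits leave unreadable from compound 2 to compound 3, and a step that the two limits leave unreadable from compound 1 to compound 2 adds no more. All of them exchange one aromatic ring for another, and none gives a size. With no readable precedent, no firm direction or step beyond the scatter is expected in this assay. The expected step is a step that the limit leaves unreadable from compound 3 to compound 4. For compound 4 the estimated half-life is 1.2 h, with an expected range from 0.4 h to 3 h.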

Compound 4, half-life: 0.25 h
Estimate against measurement, compound 4: 4.8-fold (0.68 log units) above, outside the stated range (below it).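

At the saturated chain carbon bound to an amide-type nitrogen in a ring, the choice of ring now matters: in this assay cyclohexyl gives an at least 4.0-fold lower number from compound 3 to compound 4 (0.60 log units; beyond the scatter) and an at least 4.0-fold lower number from compound 2 to compound 4 (0.60 log units; beyond the scatter) and an at least 4.0-fold lower number from compound 1 to compound 4 (0.60 log units; beyond the scatter) for the same exchange from the other aromatic rings. For the compounds shown here, the steps among the three aromatic compounds cannot be read, and this exchange is the first to bring a value off the limit: the limit of > 1 h in this assay, at which 3 of the 4 values shown sit. Going by these compounds alone, compound 4 is the only compound here with a non-aromatic ring, so this rests on a single group, and the true size of each step remains unknown.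

Going by these compounds, it remains open how far the aromatic compounds lie past their limit, and whether the loss is particular to cyclohexyl. A plain benzyl, a pyridine ring or a cyclopentyl group at this place would help separate these readings.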